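The compounds below may be only part of what the source reports. "The series", "measured", "known", "first", "only" and "open" are said of these compounds alone.

Working notes on the series. In a functional assay on Caco-2 cells (Homo sapiens), read by MTT assay, with a stated time of 48 h (on this read-out higher numbers stand for weaker inhibition and lower numbers for stronger inhibition), compound 1 `CCN(CC)CCNC(=O)c1ccc(C(CC)(CC)c2ccc(OCC(=O)C(C)(C)C)c(C)c2)n1CC` gives 1600 nM. Compound 2 `CCN(CC)CCCNC(=O)c1ccc(C(CC)(CC)c2ccc(OCC(O)C(C)(C)C)c(C)c2)n1CC` gives 1800 nM in this assay, and compound 3 `CC[C@@H](C)[C@H](NC(=O)c1ccc(C(CC)(CC)c2ccc(OCC(=O)C(C)(C)C)c(C)c2)n1CC)C(=O)O` gives 4500 nM. Among these three numbers compound 2 stands second highest; its nearest neighbour is compound 1, within the scatter of it, and its furthest is compound 3, beyond the scatter above it. Among the compounds with values here, the one single-place step among the measured compounds is a 2.8-fold higher number from compound 1 to compound 3 (0.45 log units; beyond the scatter), a modest rise.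

Compound 4 `CCn1c(C(=O)N(C)CC(=O)O)ccc1C(CC)(CC)c1ccc(OCC(O)C(C)(C)C)c(C)c1` has not yet been measured in this assay. It differs from compound 2 in one place: (carboxymethyl)(methyl)amino in place of (3-(diethylamino)propyl)amino on a carbonyl carbon. The step that bears on it is a 2.8-fold higher number from compound 1 to compound 3 (0.45 log units; beyond the scatter), where 1-carboxy-2-methylbutyl replaced 2-(diethylamino)ethyl on an amide-type nitrogen; the change now in hand likewise lets (3-(diethylamino)propyl)amino leave and (carboxymethyl)(methyl)amino enter on a carbonyl carbon, so a rise of about the same modest size, beyond the scatter, is expected in this assay rather than no change. On that basis compound 4 is expected to give 4000 nM in this assay, with a range from 1800 nM to 9000 nM, which corresponds to an estimated step of a 2.2-fold higher number from compound 2 to compound 4 (0.35 log units; beyond the scatter). Compound 3 is the only measured anchor for this kind of change, so the estimate is held loosely.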

Compound 4, half-maximal inhibitory concentration: 31900 nM
For compound 4 the middle estimate is 8.0-fold (0.90 log units) below the measured one; measured number outside the range, above it.
By their numbers in this assay, from the lowest: compounds 1 and 2 (each within the scatter of the next); then compound 3; then compound 4.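

In this assay, the change on this carbonyl carbon gives an 18-fold higher number from compound 2 to compound 4 (1.25 log units; beyond the scatter), so the position can carry a far larger shift than a 2.8-fold higher number from compound 1 to compound 3 (0.45 log units; beyond the scatter) had suggested. In both listed steps, a group ending in diethylamino leaves, a group bearing a carboxylic acid enters and the number rises, with no compound here going against this, but the size of the rise clearly depends on the pair; compounds 1 and 3 also carry a ketone where compounds 2 and 4 carry a hydroxyl, so the two steps do not share the same surroundings. The hydrogen-bond donor and acceptor counts are equal for the leaving and entering groups and so do not separate them, and nothing on hand accounts for the size of the step.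

The compounds shown leave open how much of the step belongs to the loss of the diethylamino group, the arrival of the carboxylic acid, or the methyl on the amide nitrogen. A (3-(diethylamino)propyl)(methyl)amino group or a (carboxymethyl)amino group on the same carbonyl carbon would pull these parts apart, and a methyl ester of the acid would test the role of the free carboxylic acid.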